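The source may hold more compounds than are shown below. What is called first, only, known or untested is meant among the compounds shown, and "the series" means these compounds.

Compound 1 `CC(Oc1ccc(Oc2ccc(Cl)cc2)cc1)C(=O)Cn1nnc(-c2ccc(Cl)cc2)n1`: 6.8
Compound 2 `CC(Oc1ccc(Oc2ccc(C(F)(F)F)cc2)cc1)C(=O)Cn1nnc(-c2ccc(Cl)cc2)n1`: 7
Compound 3 `CC(Oc1ccc(-c2ccccc2)cc1)C(=O)Cn1nnc(-c2ccc(Cl)cc2)n1`: 6.1

The three measured compounds share one core and differ only at one end of it. In a physicochemical assay for lipophilicity, read by HPLC, tested at 5 mM (on this read-out higher numbers stand for higher lipophilicity and lower numbers for lower lipophilicity), compound 1 gives 6.8, the second highest of the three numbers. Its nearest neighbour is compound 2, with a number 0.20 log units higher from compound 1 to compound 2 (within the scatter). Compound 3 lies furthest away, with a number 0.70 log units lower from compound 1 to compound 3 (beyond the scatter); between compound 2 and compound 3 the gap is a number 0.90 log units lower from compound 2 to compound 3 (beyond the scatter).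

Compound 4 `CC(Oc1ccc(Oc2ccc(Cl)cc2)cc1)C(=O)Cn1nnc(-c2ccc(C(=O)O)cc2)n1` has not yet been measured in this assay. It differs from compound 1 by carboxy in place of chloro on an aromatic carbon. Within the data shown here, no measured step makes this exchange: the only step that touches the same chloro, a number 0.20 log units higher from compound 1 to compound 2 (within the scatter), swaps it for trifluoromethyl and stays within the scatter, while the steps to compound 3 alter a different part of the molecule. A close precedent is therefore missing, and the expectation rests on the change itself. A downward step, larger than any of the measured ones, is expected, so compound 4 is estimated at 4.8, within a range from 3.8 to 5.8, which means an expected step of a number 2.00 log units lower from compound 1 to compound 4 (beyond the scatter).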

Compound 4, partition coefficient: 3.3
Beside the measured number, compound 4's estimate is 1.50 log units above it; the measured number lies below the stated range.
By their numbers in this assay, from the lowest: compound 4; then compound 3; then compounds 1 and 2 (each within the scatter of the next).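

Among these compounds, until now this position had been seen with only one exchange, the trifluoromethyl of a number 0.20 log units higher from compound 1 to compound 2 (within the scatter), which left the number within the scatter. In this assay, carboxy in place of chloro gives a number 3.50 log units lower from compound 1 to compound 4 (beyond the scatter), by far the largest step among these compounds, so the group on this aromatic carbon can move the read-out strongly and the size of the move depends on which group enters. Nothing measured here explains why this exchange has so large an effect.

As far as these compounds go, it remains open whether a methyl ester or an amine at the same position would give a step of similar size or one closer to that of trifluoromethyl. From the compounds shown here alone, it is also open whether carboxy would produce the same step on compound 2 or compound 3, which differ from compound 1 at the other end of the molecule.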